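A few compounds are considered here, and "the series" means these few. Any claim that something is new, unique, unknown or untested is made for them only; others in the source may bear on it.

Compound 3 `Nc1cc(N)c2nc(-c3ccccc3)c(Oc3ccc(F)cc3)nc2c1` carries a 4-fluorophenoxy group on the shared core. In a functional assay on SR cells (Homo sapiens) for inhibition, read by sulforhodamine B assay, with a stated time of 48 h (a higher number here means a weaker inhibitor of growth, a lower number a stronger inhibitor of growth), compound 3 gives only a limit of the assay, < 100000 nM. Compound 1 `Nc1cc(N)c2nc(-c3ccccc3)c(NCc3ccc(F)cc3)nc2c1`, with a (4-fluorobenzyl)amino group at the same place, likewise gives only a limit in this assay, < 100000 nM. Compound 2 `Nc1cc(N)c2nc(-c3ccccc3)c(Sc3ccc(Cl)c(Cl)c3)nc2c1`, with a (3,4-dichlorophenyl)sulfanyl group, gives 35500 nM in this assay. Within the data shown here, because of the limit of < 100000 nM in this assay, at which 2 of the 3 values shown sit, the steps a step that the two limits leave unreadable from compound 1 to compound 3, a step that the limit leaves unreadable from compound 2 to compound 3 and a step that the limit leaves unreadable from compound 1 to compound 2 cannot be sized, so no measured step gives a readable guide. Compound 4 `Nc1cc(N)c2nc(-c3ccccc3)c(Sc3ccc(F)cc3)nc2c1` differs from compound 3 by (4-fluorophenyl)sulfanyl in place of 4-fluorophenoxy on an aromatic carbon. Guided by the sulfanyl-linked compound 2 at 35500 nM, compound 4 is expected to give 50000 nM in this assay, with an estimated range from 15000 nM to 100000 nM. The expected step that the limit leaves unreadable from compound 3 to compound 4 is therefore only a rough estimate.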

Compound 4, concentration for total growth inhibition: < 100000 nM
Compound 4 ended at the assay's limit; the forecaster's own chance of this, stated with the estimate: 40%; the middle value does not contradict the limit.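

The steps from compound 1, compound 2 and compound 3 to compound 4 cannot be read, because of one shared obstacle: the limit of < 100000 nM in this assay, at which 3 of the 4 values shown sit.

The compounds shown leave open whether (4-fluorophenyl)sulfanyl in place of 4-fluorophenoxy changes growth inhibition at all.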